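The source may report more compounds than this note shows. Statements on the series, on what has been measured and on what is new or still open speak of the compounds shown alone.

Compound 1, `CCCc1cc(N)c2cc(NC(=O)/C=C/c3ccc(O)cc3)ccc2n1`, gives 1100 nM in an assay on isolated protein for displacement of a labelled ligand from melanin-concentrating hormone receptor 1 (Homo sapiens); on this read-out lower numbers stand for stronger inhibition and higher numbers for weaker inhibition. Among the three compounds measured so far it stands second highest: the nearest number belongs to compound 3, `CCCc1cc(N)c2cc(NC(=O)CCc3ccccc3)ccc2n1`, which gives 8300 nM in this assay, a gap beyond the usual scatter, while the furthest belongs to compound 2, `CC(C)c1cc(N)c2cc(NC(=O)/C=C/c3ccc(C(F)(F)F)cc3)ccc2n1`, which gives 2.1 nM in this assay, a far larger gap. Among the measured compounds shown here, compound 2 differs from compound 1 in more than one place, so its values show only that a compound of this series can reach a very low number.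

Compound 4, `CCCc1cc(N)c2cc(NC(=O)/C=C/c3ccc(I)cc3)ccc2n1`, is not yet measured. It differs from compound 1 in one place: iodo in place of hydroxy on an aromatic carbon. For the measured compounds named here, no single-place step between measured compounds is available to gauge this change, so the expectation rests on the values of compound 1 and compound 2 alone. Given that compound 2 with its trifluoromethyl group gives 2.1 nM while compound 1 with hydroxy gives 1100 nM, a step downward beyond the scatter is expected, a 44-fold lower number from compound 1 to compound 4 (1.64 log units; beyond the scatter). Compound 4 is therefore estimated to give 25 nM in this assay, within a range from 4 nM to 200 nM.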

Compound 4, half-maximal inhibitory concentration: 2.3 nM
Compound 4: middle estimate off by 11-fold (1.04 log units), on the high side; measured number below the stated range.
By their numbers in this assay, from the lowest: compounds 2 and 4 (each within the scatter of the next); then compound 1; then compound 3.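

In this assay, among the compounds shown here, iodo in place of hydroxy gives a 480-fold lower number from compound 1 to compound 4 (2.68 log units; beyond the scatter), the first step in this set that can be read at a single place. It shows that this one position on the aromatic ring can by itself account for a very large change in number, with the rest of compound 1 left as it is. The change takes away one hydrogen-bond donor and one hydrogen-bond acceptor and adds none, but no measurement at hand tells what in this exchange produces the step.

The two groups alone do not settle whether hydroxy raises the number, iodo lowers it, or both. A plain hydrogen, chloro, methoxy or an amine at this position would separate these readings.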